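Aryl halide change at the terminal urea of compound 2

A few compounds are considered here, and "the series" means these few. Any claim that something is new, unique, unknown or untested is made for them only; others in the source may bear on it.

The series is followed in a functional assay on L1210 cells (Mus musculus) for inhibition, read by MTT assay, with a stated time of 72 h; a higher number here means a weaker inhibitor, a lower number a stronger inhibitor. Compound 1 `COc1cc(NC(C)CCCNC(=O)Nc2ccc(F)cc2)c2ncccc2c1` gives 18000 nM. Going by the values given here, compound 2 `COc1cc(NC(C)CCCNC(=O)NNC(=O)Nc2ccc(Br)cc2)c2ncccc2c1`, where the ((4-bromophenyl)carbamoyl)amino group replaces 4-fluorophenyl on an amide-type nitrogen, gives 51000 nM; that step, a 2.8-fold higher number from compound 1 to compound 2 (0.45 log units; beyond the scatter), is modest but beyond the scatter, and compound 2 therefore stands as the higher of the two numbers measured so far.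

Compound 3 `COc1cc(NC(C)CCCNC(=O)NNC(=O)Nc2cccc(Cl)c2)c2ncccc2c1` is the next member. Its difference from compound 2: 3-chlorophenyl in place of 4-bromophenyl on an amide-type nitrogen. Among the compounds with values here, no measured step changes the halogen or its place on this terminal phenyl ring; the single step on record, a 2.8-fold higher number from compound 1 to compound 2 (0.45 log units; beyond the scatter), concerns the insertion of the carbamoylamino unit, not the aryl halide, so it offers no direct guide. With the carbamoylamino unit retained, the expectation is a step within the scatter, a 1.1-fold lower number from compound 2 to compound 3 (0.05 log units; within the scatter), in no firm direction. Compound 3 is therefore estimated at 45000 nM in this assay, with a range from 18000 nM to 110000 nM.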

Compound 3, half-maximal inhibitory concentration: 27000 nM
Beside the measured number, compound 3's estimate is 1.7-fold (0.22 log units) above it; low and high end bracket the measured number.
By their numbers in this assay, from the lowest: compounds 1, 3 and 2 (each within the scatter of the next, the first and the last beyond it).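

Terminal aryl on the amide-type nitrogen: exchanging 4-bromophenyl for 3-chlorophenyl changes the halogen and its place on the ring together and gives a 1.9-fold lower number from compound 2 to compound 3 (0.28 log units; within the scatter) in this assay, so the two groups are not separated in this read-out. The earlier step, a 2.8-fold higher number from compound 1 to compound 2 (0.45 log units; beyond the scatter), is beyond the scatter, while the matching replacement with the 3-chlorophenyl group gives a 1.5-fold higher number from compound 1 to compound 3 (0.18 log units; within the scatter), so the ((4-bromophenyl)carbamoyl)amino result does not carry over to every aryl group on the carbamoylamino unit. Nothing on record gives a reason for either step.

Since halogen and ring place change together in this exchange, their separate contributions remain unresolved, and a 3-bromophenyl or a 4-chlorophenyl group would be needed to divide them. Also open, going by these compounds, is how this terminal position responds to groups other than halogens, such as a plain phenyl, a 4-methoxyphenyl or a 4-aminophenyl, and whether a longer chain in place of the present linker would change the picture.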